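Aromatic Methoxy Removal in a Macrolactam Series

The source may hold more compounds than are shown below. What is called first, only, known or untested is meant among the compounds shown, and "the series" means these compounds.

Measured so far in a functional assay on A549 cells (Homo sapiens) for inhibition; a higher number here means a weaker inhibitor of growth, a lower number a stronger inhibitor of growth:
compound 1, `CO[C@H]1C[C@H](C)Cc2cc(cc(O)c2O)NC(=O)/C(C)=C/CC[C@H](OC)[C@@H](OC(N)=O)/C(C)=C/[C@H](C)[C@H]1O`: 10300 nM
compound 2, `COc1c(O)cc2cc1C[C@@H](C)C[C@H](OC)[C@H](O)[C@@H](C)/C=C(\C)[C@H](OC(N)=O)[C@@H](OC)CC/C=C(\C)C(=O)N2`: 2720 nM

In this assay compound 1 gives 10300 nM and compound 2 gives 2720 nM. Among the compounds with values here, the single step between them is a 3.8-fold lower number from compound 1 to compound 2 (0.58 log units; beyond the scatter). Compound 2 therefore stands with the lowest of the two numbers, its nearest neighbour being compound 1.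

Compound 3, `CO[C@H]1C[C@H](C)Cc2cc(O)cc(c2)NC(=O)/C(C)=C/CC[C@H](OC)[C@@H](OC(N)=O)/C(C)=C/[C@H](C)[C@H]1O`, differs from compound 2 in one place: hydrogen in place of methoxy on an aromatic carbon. Within the data shown here, the only measured step that touches this part of the shared core is a 3.8-fold lower number from compound 1 to compound 2 (0.58 log units; beyond the scatter), and it alters the same oxygen substituent in a different way, putting a methyl on the oxygen rather than taking the methoxy away altogether. Among the measured compounds shown here, its direction is not a direct guide here, and there is no measured pair in which an aromatic methoxy is replaced by hydrogen. The expected step is accordingly small, a 1.7-fold higher number from compound 2 to compound 3 (0.22 log units; within the scatter), leaning toward a weaker inhibitor but possibly within the scatter. Compound 3 is expected to give about 4500 nM, within 1300 nM to 15000 nM.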

Compound 3, concentration for 50% growth inhibition: 2730 nM
Compound 3: middle estimate off by 1.6-fold (0.22 log units), on the high side; low and high end bracket the measured number.
By their numbers in this assay, from the lowest: compounds 2 and 3 (each within the scatter of the next); then compound 1.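

In this assay, exchanging the methoxy on this aromatic carbon for hydrogen shows no change beyond the scatter (a 1.0-fold higher number from compound 2 to compound 3 (0.00 log units; within the scatter)), so the methoxy of compound 2 is not required for a number of this size. Compound 1 carries a hydroxy at the same carbon, and replacing it with hydrogen (a 3.8-fold lower number from compound 1 to compound 3 (0.58 log units; beyond the scatter)) matches in size the step from adding a methyl to that oxygen (a 3.8-fold lower number from compound 1 to compound 2 (0.58 log units; beyond the scatter)), so the free hydroxy alone sets compound 1 apart among these three. No measurement on hand accounts for this result.

As far as these compounds go, whether a fluorine, an amine or a longer chain such as ethoxy at this carbon would also leave the number unchanged remains open. Within the data shown here, the hydroxy retained in all three compounds is also untested, as no compound here changes it.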